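A Fluorine Added to a Compound Already at the Limit

This account rests on a few compounds, and the source may have more. Where it says the series, first, only, none or still open, it means among the compounds named here.

Compound 2 `CC(C)[C@H](NC(=O)COc1cccc2ccccc12)C(=O)N[C@@H](CC(=O)O)C(=O)COc1cccc(C(F)(F)F)c1` stands at the edge of what a functional assay on Jurkat cells (Homo sapiens) (a lower number here means a stronger inhibitor, a higher number a weaker inhibitor), can report: compound 2 gives > 100000 nM, which is a limit rather than a number (the limit of > 100000 nM in this assay, at which 1 of the 2 values shown sits). Among the compounds with values here, compound 1 `CC(C)[C@H](NC(=O)COc1cccc2ccccc12)C(=O)N[C@@H](CC(=O)O)C(=O)COc1ccc(-c2ccccc2)cc1` gives 87900 nM in this assay, and the only measured step is an at least 1.1-fold higher number from compound 1 to compound 2 (0.05 log units; that floor lies within the scatter). Compound 3 `CC(C)[C@H](NC(=O)COc1cccc2ccccc12)C(=O)N[C@@H](CC(=O)O)C(=O)COc1cccc(C(F)(F)F)c1F` differs from compound 2 by fluoro in place of hydrogen on an aromatic carbon. Within the data shown here, no measured step covers this change, and the one known step was small, so no shift beyond the scatter is expected in this assay. Compound 3 is estimated at 150000 nM, between 50000 nM and 500000 nM. The expected step is a step that the limit leaves unreadable from compound 2 to compound 3.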

Compound 3, half-maximal inhibitory concentration: 50400 nM
Compound 3: the middle estimate sits 3.0-fold (0.47 log units) above what was measured, within the range that was stated.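

With fluoro ortho to a trifluoromethyl group, this assay shows an at least 1.9-fold lower number from compound 2 to compound 3 (0.29 log units; that floor lies within the scatter) and returns a real number instead of a limit. Compound 2 holds a limit of the assay, so that step has only a floor: the limit of > 100000 nM in this assay, at which 1 of the 3 values shown sits. Set against 4-phenylphenyl, the 2-fluoro-3-(trifluoromethyl)phenyl group gives a 1.7-fold lower number from compound 1 to compound 3 (0.24 log units; within the scatter) and cannot be told apart from it here.

From the compounds shown here alone, how large the fluoro step truly is stays open. Nor do the compounds shown say how chloro or methoxy would behave on the same ring carbon.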